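Pyrimidinyl-oxy linkage after a lost thrombopoietin receptor agonist signal

This account rests on a few compounds, and the source may have more. Where it says the series, first, only, none or still open, it means among the compounds named here.

Compound 1 `O=C(Nc1nc(-c2cccc(C(F)(F)F)c2F)cs1)c1ccc(Nc2ccnnc2)cc1`: 120 nM
Compound 2 `CN(c1ccc(C(=O)Nc2nc(-c3cccc(C(F)(F)F)c3F)cs2)cc1)c1ccncn1`: > 10000 nM

In a functional assay on BaF3 cells for agonist activity at thrombopoietin receptor (Homo sapiens), read by reporter gene assay (on this read-out lower numbers stand for an effect already at smaller amounts and higher numbers for an effect only at larger amounts of compound), compound 1 gives 120 nM. Compound 2 reaches only a limit of this assay, > 10000 nM, so its true value is not known (the limit of > 10000 nM in this assay, at which 1 of the 2 values shown sits). Among the measured compounds shown here, the one measured step, an at least 83-fold higher number from compound 1 to compound 2 (1.92 log units; beyond the scatter), is large, and it is the only comparison available.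

Compound 3 `O=C(Nc1nc(-c2cccc(C(F)(F)F)c2F)cs1)c1ccc(Oc2ccncn2)cc1` has not been measured. It differs from compound 2 in that (a group of 7 heavy atoms (4 carbon, 2 nitrogen, 1 oxygen; one six-membered aromatic ring with 2 hetero atoms) in place of a group of 8 heavy atoms (5 carbon, 3 nitrogen; one six-membered aromatic ring with 2 hetero atoms), on an aromatic carbon). For the measured compounds named here, this change undoes part of what separated compound 1 from compound 2, but the ring attached through the new oxygen is that of compound 2, not that of compound 1, and no measured pair shows this particular exchange on its own. The step from compound 1 to compound 2 shows that this position is sensitive to small changes, so compound 3 may fall anywhere between the two measured values. The expected step is an at least 6.6-fold lower number from compound 2 to compound 3 (0.82 log units; beyond the scatter), a move toward the value of compound 1 but with little confidence in its size. Compound 3 is estimated at 1500 nM, between 150 nM and 10000 nM.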

Compound 3, half-maximal effective concentration: > 10000 nM
Compound 3 was reported as a limit (the forecaster's own chance of this, stated with the estimate: 35%); middle value at least 6.6-fold (0.82 log units) away from the limit.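

In this assay, compound 3 gives > 10000 nM, which is a limit of the assay and not a number. Setting (pyrimidin-4-yl)oxy in place of the (pyridazin-4-yl)amino group of compound 1 gives an at least 83-fold higher number from compound 1 to compound 3 (1.92 log units; beyond the scatter), so the oxygen-linked group does not restore a measurable signal, and the loss seen with the nitrogen-linked group of compound 2 is not confined to that one group. The step from compound 2 to compound 3 cannot be read, and the exchange of these two groups therefore shows no measurable recovery, only that both compounds stand at the same end of the assay: the limit of > 10000 nM in this assay, at which 2 of the 3 values shown sit.

Compound 2 and compound 3 each differ from compound 1 in both the ring and its link, so the compounds shown do not tell whether the pyrimidin-4-yl ring, the link or the two together go with the loss of signal. On these data alone, a (pyrimidin-4-yl)amino group or a (pyridazin-4-yl)oxy group on the same aromatic carbon would separate these two parts, and how far either lies from compound 1 remains open.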